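Compound 2 loses its carboxy group

The compounds below may be only part of what the source reports. "The series", "measured", "known", "first", "only" and "open" are said of these compounds alone.

Measured in a functional assay on HT-29 cells (Homo sapiens) for inhibition, with a stated time of 72 h; a higher number here means a weaker inhibitor, a lower number a stronger inhibitor:
- compound 1 `CCCn1ccc2cc(C(=O)c3cc(OC)c(OC)c(OC)c3)ccc21`: 1800 nM
- compound 2 `COc1cc(C(=O)c2ccc3c(ccn3CC(=O)O)c2)cc(OC)c1OC`: 460 nM

Of these two, compound 2 holds the lower number in this assay, at 460 nM. Compound 3 `COc1cc(C(=O)c2ccc3c(ccn3CCN(C)C)c2)cc(OC)c1OC` differs from it in one place: (dimethylamino)methyl in place of carboxy on a saturated chain carbon bound to an aromatic nitrogen. Here (dimethylamino)methyl stands in place of carboxy on a saturated chain carbon bound to an aromatic nitrogen. Within the data shown here, one measured step bears on this change, and it lies at the same place: a 3.9-fold lower number from compound 1 to compound 2 (0.59 log units; beyond the scatter). That modest step brought the carboxy in, and compound 3 gives the carboxy up again. Among the measured compounds shown here, no measured compound carries the entering group, so the expectation stays loose. A modest move toward a higher number is expected, a 1.6-fold higher number from compound 2 to compound 3 (0.21 log units; within the scatter). For compound 3 the estimated value is 750 nM, with an expected range of 150 nM to 3000 nM.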

Compound 3, half-maximal inhibitory concentration: 4600 nM
For compound 3 the middle estimate is 6.1-fold (0.79 log units) below the measured one, and the stated range ends below it.
By their numbers in this assay, from the lowest: compound 2; then compound 1; then compound 3.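

In this assay, the exchange of carboxy for (dimethylamino)methyl on a saturated chain carbon bound to an aromatic nitrogen gives a 10-fold higher number from compound 2 to compound 3 (1.00 log units; beyond the scatter) and shows that this position can also move the number upward, whereas the earlier pair had shown only a fall. Dimethylamino in place of methyl on a saturated chain carbon, two bonds along the chain from an aromatic nitrogen, gives a 2.6-fold higher number from compound 1 to compound 3 (0.41 log units; beyond the scatter) and places the amine-bearing chain above the plain propyl chain of compound 1 as well as above the carboxy chain of compound 2. Nothing available here explains these differences.

Going by these compounds, it remains open whether a carboxylic acid on a longer chain would hold or lower the number seen with compound 2 at 460 nM in this assay and whether a primary amine or an amide at the chain end would follow compound 3.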